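The source may report more compounds than this note shows. Statements on the series, on what has been measured and on what is new or still open speak of the compounds shown alone.

In a functional assay on MGC-803 cells (Homo sapiens) for inhibition, read by sulforhodamine B assay (on this read-out higher numbers stand for weaker inhibition and lower numbers for stronger inhibition), compound 1 `COc1ccccc1NC1=CC(=O)c2c(nc3n2[C@H]2OC[C@@H](O)[C@H]2OC3)C1=O` gives 1670 nM. Among the compounds with values here, compound 2 `O=C1C(Nc2ccc(C(F)(F)F)cc2)=CC(=O)c2c1nc1n2[C@H]2OC[C@@H](O)[C@H]2OC1` gives 1860 nM, which places it within the scatter of the only other number available. Compound 3 `O=C1C(NCc2ccccc2)=CC(=O)c2c1nc1n2[C@H]2OC[C@@H](O)[C@H]2OC1` keeps the shared core and differs from compound 2 at one place: benzyl in place of 4-(trifluoromethyl)phenyl on an amine nitrogen. In words, this is benzyl in place of 4-(trifluoromethyl)phenyl on an amine nitrogen.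

Within the data shown here, only one measured step bears on this change. It also concerns the group on that nitrogen, with 4-(trifluoromethyl)phenyl in place of 2-methoxyphenyl, and it amounts to a 1.1-fold higher number from compound 1 to compound 2 (0.05 log units; within the scatter). That exchange left this assay without a change beyond the scatter, so it offers no reason to expect a large move here. Among the measured compounds shown here, the support is thin, however, as no measured compound carries benzyl and one step is little to go on. The expected result is a 1.1-fold higher number from compound 2 to compound 3 (0.03 log units; within the scatter), which would be no change beyond the scatter. For compound 3 the estimated value is 2000 nM, with an expected range from 800 nM to 5000 nM.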

Compound 3, half-maximal inhibitory concentration: 3490 nM
Estimate against measurement, compound 3: 1.7-fold (0.24 log units) below, and the stated range covers the measured number.
By their numbers in this assay, from the lowest: compounds 1, 2 and 3 (each within the scatter of the next, the first and the last beyond it).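

Within the data shown here, the first step at this position to pass the scatter in this assay is benzyl in place of 2-methoxyphenyl on an amine nitrogen, with a 2.1-fold higher number from compound 1 to compound 3 (0.32 log units; beyond the scatter), and it is only a modest step. Benzyl in place of 4-(trifluoromethyl)phenyl gives a 1.9-fold higher number from compound 2 to compound 3 (0.27 log units; within the scatter), so the same entering group stays inside the scatter against one of the two earlier groups and just passes it against the other, and all three groups on this nitrogen remain close in this assay. No evidence is available on what lies behind these steps.

All three groups carry one six-membered aromatic ring of carbon only, so the compounds shown leave open how this assay responds to a group on this nitrogen without such a ring, such as a plain alkyl chain or a cyclohexyl group. They also leave open what a 2-phenylethyl group would do, and whether an amine or a carboxylic acid on the ring of the benzyl group would move the number further than these modest differences.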